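Nitro to Trifluoromethoxy on a Styryl Benzyl Sulfone

The source may hold more compounds than are shown below. What is called first, only, known or untested is meant among the compounds shown, and "the series" means these compounds.

Measured so far:
compound 1 `COc1cc(OC)c(/C=C/S(=O)(=O)Cc2cc(OC)c(OC)c(OC)c2)c(OC)c1` gives > 20000 nM in a functional assay on H157 cells (Homo sapiens) for antiproliferative activity, read by trypan blue exclusion; a lower number here means a stronger inhibitor, a higher number a weaker inhibitor
compound 2 `COc1cc(OC)c(/C=C/S(=O)(=O)Cc2ccc([N+](=O)[O-])cc2)c(OC)c1` gives 20000 nM in this assay
compound 3 `COc1ccc(CS(=O)(=O)/C=C/c2ccc(F)cc2)cc1` gives 2500 nM in this assay

The figure for compound 1 is a limit of the assay, not a number. Going by the values given here, of the two actual numbers, compound 2 stands highest, and the only other number, that of compound 3, lies lower by a gap beyond the usual scatter. Compound 4 `COc1cc(OC)c(/C=C/S(=O)(=O)Cc2ccc(OC(F)(F)F)cc2)c(OC)c1` differs from compound 2 in one place: trifluoromethoxy in place of nitro on an aromatic carbon. Among the compounds with values here, no measured pair covers this change, so the step from compound 2 to compound 4 is expected to be a 2.0-fold lower number from compound 2 to compound 4 (0.30 log units; within the scatter), a small move toward a lower number that may not rise above the scatter. Compound 4 is therefore estimated at 10000 nM, with a range from 2000 nM to 40000 nM.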

Compound 4, half-maximal inhibitory concentration: 6000 nM
Compound 4: the middle estimate sits 1.7-fold (0.22 log units) above what was measured; the range from low to high includes it.
By their numbers in this assay, from the lowest: compound 3; then compound 4; then compound 2.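

Trifluoromethoxy in place of nitro gives a 3.3-fold lower number from compound 2 to compound 4 (0.52 log units; beyond the scatter) in this assay, a modest step that shows the group on this aromatic carbon, para to a large group, can shift the result on this core. The step starts from a number that equals the figure of the assay's limit: the limit of > 20000 nM in this assay, at which 1 of the 4 values shown sits.

From the compounds shown here alone, how an amine or a carboxylic acid on this carbon would compare remains open. A single pair also cannot tell which difference between nitro and trifluoromethoxy accounts for the step, or whether it would carry over to another core.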